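Pyridyl Amide in the Rat Paw Edema Series

The source may report more compounds than this note shows. Statements on the series, on what has been measured and on what is new or still open speak of the compounds shown alone.

Three amides of a shared core have been measured in a functional assay on the whole organism for inhibition, with Rattus norvegicus as the target, read by paw edema, at a dose of 100 mg/kg by the oral route; a higher number here means more inhibition at the dose given (going by the name of the read-out), a lower number less inhibition. Compound 1 `O=C(NCc1ccccc1)c1c(O)c2cccnc2n(-c2ccccc2)c1=O` gives 1.6%. Compound 2 `O=C(Nc1ccccc1)c1c(O)c2cccnc2n(-c2ccccc2)c1=O` gives 4.6%, and compound 3 `Cc1ccc(NC(=O)c2c(O)c3cccnc3n(-c3ccccc3)c2=O)cc1` gives -3.5%. Compound 3 stands at the low end of the three numbers, yet both steps towards it, a number 5.1 percentage points lower from compound 1 to compound 3 (within the scatter) and a number 8.1 percentage points lower from compound 2 to compound 3 (within the scatter), stay within the scatter, as does a number 3 percentage points higher from compound 1 to compound 2 (within the scatter); the three numbers cannot be told apart.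

Compound 4 `Cc1cnccc1NC(=O)c1c(O)c2cccnc2n(-c2ccccc2)c1=O` is yet to be measured. It differs from compound 3 in one place: 3-methylpyridin-4-yl in place of 4-methylphenyl on an amide-type nitrogen. Among the measured compounds shown here, no measured step trades a ring of carbon only for one with a hetero atom at this position; the nearest comparisons are the changes of the group on the amide-type nitrogen among compounds 1, 2 and 3, none of which left the scatter. On that basis compound 4 is expected to show a number 4.5 percentage points higher from compound 3 to compound 4 (within the scatter), nothing beyond the scatter. The estimate for compound 4 is 1%, within -9% to 11%.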

Compound 4, a percentage reported as inhibition, in the whole organism at one dose (the size of the read-out at that dose, not a potency): 26.9%
The estimate for compound 4 lay 25.9 percentage points below the measured number; the whole stated range lies below it.
By their numbers in this assay, from the lowest: compounds 3, 1 and 2 (each within the scatter of the next); then compound 4.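

In this assay, among the compounds shown here, the group on the amide-type nitrogen had so far made no readable difference, yet 3-methylpyridin-4-yl in place of 4-methylphenyl gives a number 30.4 percentage points higher from compound 3 to compound 4 (beyond the scatter) and is the first change here to leave the scatter. For the compounds shown here, the same group also stands apart from the other two amides, with a number 22.3 percentage points higher from compound 2 to compound 4 (beyond the scatter) and a number 25.3 percentage points higher from compound 1 to compound 4 (beyond the scatter) as the steps, so this position can move the read-out, and the one group that does so is the one whose ring holds a hetero atom and which counts a hydrogen-bond acceptor. Nothing available explains why this exchange has such an effect.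

The compounds shown leave open whether the ring nitrogen suffices or whether the step also depends on the methyl of 3-methylpyridin-4-yl. They also leave open what an amine or a carboxylic acid on that ring would do.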